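Halogen Swap on an Inactive Analogue of a Shared Core

A few compounds are considered here, and "the series" means these few. Any claim that something is new, unique, unknown or untested is made for them only; others in the source may bear on it.

For the measured compounds named here, compound 1 `COc1ccccc1/C=c1\c(=O)[nH]/c(=C/c2ccccc2Cl)c(=O)n1C` and compound 2 `C=CCn1c(=O)/c(=C\c2ccc(F)c(Br)c2)[nH]c(=O)/c1=C\c1ccccc1OC` share one core and differ at more than one place, so no single step can be drawn between them. In a functional assay on A549 cells (Homo sapiens) for cytotoxicity, read by CCK-8 assay, with a stated time of 72 h (on this read-out lower numbers stand for stronger inhibition and higher numbers for weaker inhibition), compound 1 gives 300 nM. In this assay compound 2 is reported as "not active" (no number reported), with no number attached, so on the numbers shown it stands without a measured potency and offers no quantitative anchor of its own. Compound 3 `C=CCn1c(=O)/c(=C\c2ccc(Cl)c(Cl)c2)[nH]c(=O)/c1=C\c1ccccc1OC` follows from compound 2 by a single change: 3,4-dichlorophenyl in place of 3-bromo-4-fluorophenyl on a double-bonded chain carbon bound to an aromatic carbon. Going by the values given here, no measured pair shows the size of such a step in this assay, and no direction can be read from the two values at hand, so the expectation rests on compound 2 alone. Given that compound 2 in this assay is "not active" (no number reported), compound 3 is expected to remain weak, with an estimated value of 20000 nM and a range from 3000 nM to 100000 nM.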

Compound 3, half-maximal inhibitory concentration: "not active" (no number reported)
Compound 3: no number reported; the estimate stays without a comparison.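

Compound 2 and compound 3 both stand without a number in this assay, so no step can be read between them. The compounds shown leave open which of the places where compound 1 differs from compound 2 matters for activity. No evidence shown bears on this result.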